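The compounds below may be only part of what the source reports. "The series", "measured", "known", "first", "only" and "open" are said of these compounds alone.

Compound 1 `C[C@@H](NC(=O)C1(NC(=O)c2cncc(Cl)c2)CC1)c1ccc(-n2nc(Cl)c3ccccc32)cc1F` is measured in an in vivo ADME assay on the whole organism (strain Mongrel) for pharmacokinetics, with Canis familiaris (Canis lupus familiaris) as the target (on this read-out higher numbers stand for fast clearance and lower numbers for slow clearance), at 3.1 mL/min/kg. Its two neighbours, compound 2 `COc1cncc(C(=O)NC2(C(=O)N[C@H](C)c3ccc(-n4nc(Cl)c5ccccc54)cc3F)CC2)c1` at 5.5 mL/min/kg and compound 3 `C[C@@H](NC(=O)C1(NC(=O)c2cncc(Br)c2)CC1)c1ccc(-n2nc(Cl)c3ccccc32)cc1F` at 3.8 mL/min/kg, sit within the scatter of it, so the three stand as one cluster on this assay. The step to compound 4 `COc1cc(C(=O)NC2(C(=O)N[C@H](C)c3ccc(-n4nc(Cl)c5ccccc54)cc3F)CC2)on1` is 3-methoxy-1,2-oxazol-5-yl in place of 5-chloropyridin-3-yl on a carbonyl carbon. The measured steps touching this ring are a 1.8-fold higher number from compound 1 to compound 2 (0.25 log units; within the scatter), a 1.2-fold higher number from compound 1 to compound 3 (0.09 log units; within the scatter) and a 1.4-fold lower number from compound 2 to compound 3 (0.16 log units; within the scatter); none moved the clearance beyond the scatter. Those were substituent swaps, while the step to compound 4 exchanges the whole ring, so the estimate is a small rise, a 1.6-fold higher number from compound 1 to compound 4 (0.21 log units; within the scatter), with wide uncertainty. Compound 4 is therefore expected at about 5 mL/min/kg, between 2 mL/min/kg and 12 mL/min/kg.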

Compound 4, clearance: 1.3 mL/min/kg
Compound 4: the middle estimate sits 3.8-fold (0.59 log units) above what was measured, outside the stated range (below it).
By their numbers in this assay, from the lowest: compound 4; then compounds 1, 3 and 2 (each within the scatter of the next).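

Substituent swaps on the six-membered aromatic ring had left the clearance in this assay within the scatter, but replacing the ring itself on this carbonyl carbon moves it beyond the scatter against all three earlier compounds (a 2.4-fold lower number from compound 1 to compound 4 (0.38 log units; beyond the scatter); a 2.9-fold lower number from compound 3 to compound 4 (0.47 log units; beyond the scatter); a 4.2-fold lower number from compound 2 to compound 4 (0.63 log units; beyond the scatter)). The 3-methoxy-1,2-oxazol-5-yl group therefore separates from the cluster, on the side of slower clearance. Nothing available accounts for this shift. On these data alone, compound 4 alone carries this ring, so whether the lower number follows the ring or its methoxy stays open. A 1,2-oxazol-5-yl group with methyl or with no substituent would separate the two.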